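Two non-toxic amides and a swap on the nitrogen

The compounds below may be only part of what the source reports. "The series", "measured", "known", "first", "only" and "open" are said of these compounds alone.

Compound 1: `Cc1cc(C)cc(NC(=O)COc2cc(C)nc3ccc(C(F)(F)F)cc23)c1`; in a toxicity assay on HepG2 cells (Homo sapiens) for inhibition, read by CellTiter-Glo, with a stated time of 48 h (a higher number here means a weaker inhibitor, a lower number a stronger inhibitor), compound 1 gives only a limit, > 100000 nM.
Compound 2: `COc1ccc2nc(C)cc(OCC(=O)NCc3cc(C)cc(C)c3)c2c1`; in this assay compound 2 gives only a limit, > 100000 nM.

Compound 2 stands at the limit of the measurement rather than at a number; both values known here are limits, and (the limit of > 100000 nM in this assay, at which 2 of the 2 values shown sit). Compound 3, `COc1ccc2nc(C)cc(OCC(=O)Nc3c(C)cccc3C)c2c1`, differs from compound 2 in one place: 2,6-dimethylphenyl in place of 3,5-dimethylbenzyl on an amide-type nitrogen. Within the data shown here, no step between measured compounds is available, so no measured pair shows how large such a change can be. With both known values sitting at the limit and the change confined to the group on the amide nitrogen, the expectation for compound 3 is that it stays at or near that limit in this assay, with no step beyond the usual scatter in either direction. The expected step is a step that the limit leaves unreadable from compound 2 to compound 3. For compound 3 the estimate in this assay is 150000 nM, within a range from 40000 nM to 600000 nM, and the likeliest outcome is that once more only a limit is reported.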

Compound 3, half-maximal inhibitory concentration: > 100000 nM
Compound 3: only a limit was reported; the forecaster's own chance of this, stated with the estimate: 85%; the middle value lies beyond the limit too.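

Compound 2 and compound 3 both stand at a limit in this assay, so no step can be read for 2,6-dimethylphenyl in place of 3,5-dimethylbenzyl on the amide-type nitrogen: the limit of > 100000 nM in this assay, at which 3 of the 3 values shown sit.

The compounds shown leave open whether any such amide reaches a measurable value in this assay, and how large a step this swap can produce.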